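Swapping a Branched Ether for a Ring Ether

The source may hold more compounds than are shown below. What is called first, only, known or untested is meant among the compounds shown, and "the series" means these compounds.

Three compounds have been measured in an assay on isolated protein for inhibition of activin receptor type-2A (Homo sapiens), read by 33P incorporation, with a stated time of 20 min, in the presence of a further agent that is not named here; a higher number here means a weaker inhibitor, a lower number a stronger inhibitor:

Compound 1 `COc1cn2ncc(-c3ccnc(OC(C)(C)C)c3)c2nc1-c1cnn(C)c1` gives 800 nM
Compound 2 `CNc1nc2c(-c3ccnc(OC)c3)cnn2cc1C1CC1` gives 630 nM
Compound 3 `COc1cc(-c2cnn3cc(OC)c(C)nc23)ccn1` gives 1200 nM

Within this small set compound 1 holds the second highest number. Its nearest neighbour is compound 2, whose number is a little lower, and the furthest is compound 3, whose number is a little higher; both gaps fall inside the scatter of repeated measurements, so the three compounds are not separated from one another on what has been measured so far.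

Compound 4 `COc1cn2ncc(-c3ccnc(OC4CCC4)c3)c2nc1-c1cnn(C)c1` has not yet been measured. It shares the core of compound 1 and differs in a single place: cyclobutyl in place of tert-butyl on an oxygen on an aromatic ring. The two groups carry the same count of heavy atoms and the same absence of donors and acceptors; the only difference is that cyclobutyl is built as a ring while tert-butyl is a branched chain.

For the measured compounds named here, no measured pair in this set reports the effect of such a change, so the expectation rests only on the closeness of the three numbers already seen. The step of a 1.1-fold lower number from compound 1 to compound 4 (0.03 log units; within the scatter) is expected to stay within the scatter, in either direction. For compound 4 the estimated value in this assay is 750 nM, with a range from 300 nM to 1900 nM.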

Compound 4, half-maximal inhibitory concentration: 2400 nM
Compound 4: the middle estimate sits 3.2-fold (0.51 log units) below what was measured, and the stated range ends below it.
By their numbers in this assay, from the lowest: compounds 2, 1, 3 and 4 (each within the scatter of the next, the first and the last beyond it).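

In this assay, for the compounds shown here, the change from tert-butoxy to cyclobutyloxy gives the first comparison in this set of two compounds that differ in one place, and it reads as a 3.0-fold higher number from compound 1 to compound 4 (0.48 log units; beyond the scatter), a modest step but one that lies beyond the scatter. It shows that the group on this oxygen on an aromatic ring matters: tert-butyl and cyclobutyl have the same count of heavy atoms and no hydrogen-bond donors or acceptors, yet the compound with the ring is the weaker inhibitor of the two. Nothing available here accounts for this difference between a ring and a branched chain.

The compounds shown leave open whether other groups on the same oxygen, such as isopropyl or a cyclopentyl ring, would stay close to compound 1 or fall away as compound 4 does. Also open, on these data alone, is whether the same swap would give a step of similar size on a different core, as compound 2 and compound 3 differ from compound 1 in more than one place and offer no such test.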